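Chloro for methyl on the aryl ring of compound 3

The compounds below may be only part of what the source reports. "The series", "measured", "known", "first", "only" and "open" are said of these compounds alone.

Among the compounds with values here, compound 3 `Cc1ccc(-c2cc(N3CCC(CCNS(N)(=O)=O)CC3)ncn2)cc1` gives 47500 nM in a functional assay on MCF7 cells (Homo sapiens) for antiproliferative activity, read by sulforhodamine B assay, with a stated time of 48 h (on this read-out lower numbers stand for stronger inhibition of growth and higher numbers for weaker inhibition of growth), the highest of the three numbers measured so far. Compound 1 `Cc1ccc(-c2cc(N3CCC(CNS(N)(=O)=O)CC3)ncn2)cc1` gives 30600 nM, and the gap a 1.6-fold higher number from compound 1 to compound 3 (0.19 log units; within the scatter) lies within the scatter. Within the data shown here, compound 2 `COc1ccccc1-c1cc(N2CCC(CNS(N)(=O)=O)CC2)ncn1` gives 10100 nM; the step of a 3.0-fold lower number from compound 1 to compound 2 (0.48 log units; beyond the scatter) is the only measured change at the aryl ring. Compound 4 `NS(=O)(=O)NCCC1CCN(c2cc(-c3ccc(Cl)cc3)ncn2)CC1` differs from compound 3 by chloro in place of methyl on an aromatic carbon. Among the measured compounds shown here, no measured step exchanges methyl for chloro, and the single aryl change seen was modest, so the expectation in this assay is a step within the scatter, or at most a little beyond it, in either direction. For compound 4 the estimate is 40000 nM, with a range from 15000 nM to 120000 nM, meaning an expected step of a 1.2-fold lower number from compound 3 to compound 4 (0.07 log units; within the scatter).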

Compound 4, concentration for 50% growth inhibition: 19700 nM
For compound 4 the middle estimate is 2.0-fold (0.31 log units) above the measured one, and the stated range covers the measured number.
By their numbers in this assay, from the lowest: compounds 2, 4, 1 and 3 (each within the scatter of the next, the first and the last beyond it).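

With chloro in place of methyl on the aromatic carbon para to a large group, the series shows a 2.4-fold lower number from compound 3 to compound 4 (0.38 log units; beyond the scatter) in this assay. The 4-methylphenyl group of compound 3 is therefore not neutral to exchange, as a swap of one heavy atom at this place moves the number beyond the scatter. No measured data bear on the cause of this step. 

From the compounds shown here alone, it remains open whether 4-chlorophenyl gives a similar step on the chain of compound 1. Also open, going by these compounds, is how an amine or a carboxylic acid would read at this place.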